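Moving the trifluoromethyl group around the phenyl ring

The source may report more compounds than this note shows. Statements on the series, on what has been measured and on what is new or still open speak of the compounds shown alone.

Compounds measured in an assay (strain Wistar) for displacement of a labelled ligand from adenosine receptor A1 (Rattus norvegicus), read by scintillation counting; on this read-out lower numbers stand for stronger inhibition and higher numbers for weaker inhibition:
compound 1 `O=C(Nc1nc(-c2ccccc2)nc2c1nnn2Cc1ccccc1)C1CCCCC1`: 12 nM
compound 2 `O=C(Nc1nc(-c2ccccc2)nc2c1nnn2Cc1ccccc1)c1ccccc1C(F)(F)F`: 550 nM
compound 3 `Nc1nc(-c2ccccc2)nc2c1nnn2Cc1ccccc1`: 5.6 nM

Compound 2 gives the highest number of the three. From it, the step of a 46-fold higher number from compound 1 to compound 2 (1.66 log units; beyond the scatter) shows the largest change seen here, while a 2.1-fold lower number from compound 1 to compound 3 (0.33 log units; beyond the scatter) is modest. Compound 4 `O=C(Nc1nc(-c2ccccc2)nc2c1nnn2Cc1ccccc1)c1ccc(C(F)(F)F)cc1` has the same atoms as compound 2, joined differently: 4-(trifluoromethyl)phenyl in place of 2-(trifluoromethyl)phenyl on a carbonyl carbon. For the measured compounds named here, no measured pair shows this kind of change, so the direction is uncertain; the only guide is that compound 2 sits far above compound 1 and compound 3, leaving room for a lower number. A step of a 2.8-fold lower number from compound 2 to compound 4 (0.44 log units; beyond the scatter) toward a lower number is expected, with wide uncertainty. For compound 4 the estimate in this assay is 200 nM, between 40 nM and 1500 nM.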

Compound 4, inhibition constant: 123 nM
Compound 4: the middle estimate sits 1.6-fold (0.21 log units) above what was measured; the range from low to high includes it.
By their numbers in this assay, from the lowest: compound 3; then compound 1; then compound 4; then compound 2.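

In this assay, moving the trifluoromethyl group on the phenyl ring matters on its own, with no atom gained or lost: there is a 4.5-fold lower number from compound 2 to compound 4 (0.65 log units; beyond the scatter). Even the better placement does not match the cyclohexyl group on the carbonyl carbon, with a 10-fold higher number from compound 1 to compound 4 (1.01 log units; beyond the scatter). Nothing measured here gives a reason for the difference between the two placements. Still open, as far as these compounds go, is whether an amine or a carboxylic acid in place of the trifluoromethyl group would close that remaining gap.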